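Removing a hydroxy group from a lipophilicity series

The source may report more compounds than this note shows. Statements on the series, on what has been measured and on what is new or still open speak of the compounds shown alone.

Measured so far:
- Compound 1, `CNC(=O)c1cc(C(=O)NC)c2c(c1)[C@](C)(c1ccccc1)CO2`: 3.4
- Compound 2, `CNC(=O)c1cc(C(=O)N[C@H]2[C@@H]3COC[C@@H]32)cc2c1OC[C@@]2(CO)c1ccccc1`: 2.4
- Compound 3, `CNC(=O)c1cc(C(=O)N[C@H]2C[C@@H]2C)cc2c1OC[C@@]2(CO)c1ccccc1`: 3.3

These three compounds were tested in a physicochemical assay for lipophilicity, at pH 7.4; on this read-out lower numbers stand for lower lipophilicity and higher numbers for higher lipophilicity. Compound 2 stands lowest of the three; compound 3 is its nearest neighbour and compound 1 lies furthest from it. Among the measured compounds shown here, the only one-place step among the measured compounds, a number 0.90 log units higher from compound 2 to compound 3 (beyond the scatter), concerns the group on the amide-type nitrogen and leaves the hydroxymethyl untouched.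

Compound 4, `CNC(=O)c1cc(C(=O)N[C@H]2[C@@H]3COC[C@@H]32)cc2c1OC[C@@]2(C)c1ccccc1`, has not yet been measured. It differs from compound 2 in one place, (hydrogen in place of hydroxy on a saturated chain carbon bound to a saturated ring carbon). For the measured compounds named here, no measured pair isolates this change: compound 1 carries a methyl at the same place, but it differs from compound 2 in the amide group as well, so the gap between their values cannot be assigned to either change alone. Going by the values given here, the step from compound 2 to compound 3 shows only that the shared core tolerates a shift in this assay of modest size when one group is exchanged.

Among the compounds with values here, with no direct precedent, the step from compound 2 to compound 4 is expected to be a number 0.80 log units higher from compound 2 to compound 4 (beyond the scatter), an increase beyond the scatter. Compound 4 is therefore estimated at 3.2, within 2.6 to 3.8.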

Compound 4, distribution coefficient: 3.7
The estimate for compound 4 lay 0.50 log units below the measured number, within the range that was stated.
By their numbers in this assay, from the lowest: compound 2; then compounds 3, 1 and 4 (each within the scatter of the next, the first and the last beyond it).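

In this assay, hydrogen in place of hydroxy on a saturated chain carbon bound to a saturated ring carbon, which can also be read as hydroxymethyl to methyl, gives a number 1.30 log units higher from compound 2 to compound 4 (beyond the scatter). This is the first pair shown that isolates the change, so the effect of this one position on the read-out can now be stated on its own, without an amide change mixed into it. With the methyl in place, the pair that differs only on the amide-type nitrogen, where a group of 6 heavy atoms stands in place of one carbon atom, gives a number 0.30 log units higher from compound 1 to compound 4 (within the scatter), and nothing among the data shown explains the size of either step.

Going by these compounds, the hydroxy change is seen here with a single amide group, so it remains open whether the same step would appear with the amide group of compound 3. Also open, on these data alone, is where a methoxymethyl, an aminomethyl or a carboxylic acid at this place would fall relative to compound 2 and compound 4.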